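Furan for Phenyl on the Longer-Chain Amide

The compounds below may be only part of what the source reports. "The series", "measured", "known", "first", "only" and "open" are said of these compounds alone.

Compound 1, `CCCCCCCCNC(=O)[C@@H](NC(=O)c1ccccc1)[C@@H](C)O`, in a functional assay on SW-620 cells (Homo sapiens) for cytotoxicity, read by MTT assay, with a stated time of 48 h; on this read-out lower numbers stand for stronger inhibition and higher numbers for weaker inhibition: 200000 nM
Compound 2, `CCCCCCCCNC(=O)[C@@H](NC(=O)c1ccco1)[C@@H](C)O`, in this assay: 200000 nM
Compound 3, `CCCCCCCCCCCCNC(=O)[C@@H](NC(=O)c1ccccc1)[C@@H](C)O`, in this assay: 200000 nM

Compound 3 stands level with compound 1 and compound 2 in this assay; the step of no change at the digits printed from compound 1 to compound 3 (within the scatter) is within the scatter, and its gap to compound 2 is the same. No one of the three can be called more or less active than another on these numbers.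

Compound 4, `CCCCCCCCCCCCNC(=O)[C@@H](NC(=O)c1ccco1)[C@@H](C)O`, has not been measured. It differs from compound 3 in one place: furan-2-yl in place of phenyl on a carbonyl carbon. The same exchange has been made once before, on the shorter chain, as the step of no change at the digits printed from compound 1 to compound 2 (within the scatter), which lay within the scatter. The chain lengthening itself, no change at the digits printed from compound 1 to compound 3 (within the scatter), also lay within the scatter. Both measured steps that bear on compound 4 therefore point to no change beyond the scatter in this assay, in either direction.

On that basis compound 4 is expected to give 200000 nM in this assay, with a range from 100000 nM to 400000 nM. The expected step is no change at the digits printed from compound 3 to compound 4 (within the scatter).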

Compound 4, half-maximal inhibitory concentration: 87500 nM
Beside the measured number, compound 4's estimate is 2.3-fold (0.36 log units) above it; measured number outside the range, below it.
By their numbers in this assay, from the lowest: compound 4; then compounds 1, 2 and 3 (each within the scatter of the next).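

Compound 4 is the first of these compounds to separate from the rest in this assay. With furan-2-yl in place of phenyl on a carbonyl carbon, the longer chain gives a 2.3-fold lower number from compound 3 to compound 4 (0.36 log units; beyond the scatter), and with butyl in place of hydrogen on a saturated chain carbon, the furan-2-yl amide gives a 2.3-fold lower number from compound 2 to compound 4 (0.36 log units; beyond the scatter), so a number beyond the scatter appears only where both changes stand together. Even so, neither change can be said to work differently on one core than on the other, as the paired steps for each change do not separate: the same change on two cores in this assay, no change at the digits printed (within the scatter) from compound 1 to compound 2 and a 2.3-fold lower number (0.36 log units; beyond the scatter) from compound 3 to compound 4, 2.3-fold (0.36 log units) apart, within the scatter of two such steps; (the same change on two cores in this assay, no change at the digits printed (within the scatter) from compound 1 to compound 3 and a 2.3-fold lower number (0.36 log units; beyond the scatter) from compound 2 to compound 4, 2.3-fold (0.36 log units) apart, within the scatter of two such steps).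

The compounds shown leave open whether a still longer chain on the amide-type nitrogen would carry the number further down, or whether the step would fade, since only two chain lengths can be compared here. They also leave open whether thiophen-2-yl or pyridin-2-yl on the same carbonyl carbon would read like furan-2-yl or like phenyl on the longer chain.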